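Pyridyl for Phenyl on the Carbonyl: Cytotoxicity Outlook

The source may report more compounds than this note shows. Statements on the series, on what has been measured and on what is new or still open speak of the compounds shown alone.

Compound 1 `Cc1ccc(C(=O)n2c(-c3cn(-c4ccccc4)nc3-c3ccc(C(F)(F)F)cc3)nc3ccccc32)cc1` — 169000 nM
Compound 2 `Cc1ccc(C(=O)n2c(-c3cn(-c4ccccc4)nc3-c3ccc(F)cc3)nc3ccccc32)cc1` — 178000 nM

In an ADME assay on HEK-293T cells (Homo sapiens) for cytotoxicity, read by MTT assay, with a stated time of 24 h (a higher number here means that more compound is tolerated, a lower number that less compound is tolerated), compound 1 gives 169000 nM and compound 2 gives 178000 nM. Among the compounds with values here, the two sit within the scatter of each other, the sole measured step being a 1.1-fold higher number from compound 1 to compound 2 (0.02 log units; within the scatter). Compound 3 `Cc1ccc(C(=O)n2c(-c3cn(-c4ccccc4)nc3-c3ccc(F)cc3)nc3ccccc32)cn1` differs from compound 2 in one place: 6-methylpyridin-3-yl in place of 4-methylphenyl on a carbonyl carbon. Within the data shown here, no measured step touches the group on the carbonyl carbon, and the one step at hand, at the trifluoromethyl-bearing ring, was within the scatter. Compound 3 is therefore expected to give about 170000 nM, with a range of 80000 nM to 350000 nM. The step this estimate means is a 1.0-fold lower number from compound 2 to compound 3 (0.02 log units; within the scatter), expected to be none beyond the scatter.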

Compound 3, half-maximal cytotoxic concentration: 137000 nM
Compound 3: middle estimate off by 1.2-fold (0.09 log units), on the high side; measured number inside the range.
By their numbers in this assay, from the lowest: compounds 3, 1 and 2 (each within the scatter of the next).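

In this assay, the group on the carbonyl carbon now has a measured step of its own, and 6-methylpyridin-3-yl in place of 4-methylphenyl stays within the scatter (a 1.3-fold lower number from compound 2 to compound 3 (0.11 log units; within the scatter)). Within the data shown here, a ring nitrogen and its hydrogen-bond acceptor can thus enter at this place without a step beyond the scatter, which the earlier compounds, differing only at the trifluoromethyl-bearing ring, could not show. Nothing at hand accounts for the size of this step. On these data alone, whether an amine, a carboxylic acid or a longer chain on the group at the carbonyl carbon would give a step beyond the scatter remains open.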